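Esterification of the hydroxyl in a methylene lactone pair

The compounds below may be only part of what the source reports. "The series", "measured", "known", "first", "only" and "open" are said of these compounds alone.

Measured compounds:
compound 1, `C=C1C(=O)O[C@@H]2CC(C)=C([C@@H](C)CCCO)[C@H](O)[C@H]12`, > 100000 nM
compound 2, `C=C1C(=O)O[C@H]2/C=C(\C)CC/C=C(\C)C[C@H](O)[C@@H]12`, 56100 nM

In a functional assay on HT-29 cells (Homo sapiens) for cytotoxicity, read by trypan blue exclusion, with a stated time of 24 h (on this read-out higher numbers stand for weaker inhibition and lower numbers for stronger inhibition), compound 1 reaches only > 100000 nM, which is a limit of the assay and not a number. Compound 1 therefore stands at the limit of > 100000 nM in this assay, at which 1 of the 2 values shown sits, and its place on the scale is known only as that limit. Compound 2, a ring-expanded analogue of the same methylene lactone, gives 56100 nM in this assay. Among the compounds with values here, no step between measured compounds can be computed, so the only comparison across the measured pair is between a limit and one number.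

Compound 3, `C=C1C(=O)O[C@@H]2CC(C)=C([C@@H](C)CCCO)[C@H](OC(=O)C(C)CC)[C@H]12`, is not yet measured. It differs from compound 1 in one place: (sec-butyl)carbonyl in place of hydrogen on an oxygen on a saturated carbon. Taken as an expectation only, the step of an at least 1.6-fold lower number from compound 1 to compound 3 (0.22 log units; that floor lies within the scatter) in this assay is estimated to be a modest gain rather than none, though it rests on no measured step. Compound 3 is thus expected to give about 60000 nM, within 15000 nM to 200000 nM.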

Compound 3, half-maximal inhibitory concentration: 48100 nM
Estimate against measurement, compound 3: 1.2-fold (0.10 log units) above; low and high end bracket the measured number.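

In this assay, the change from hydroxy to ((sec-butyl)carbonyl)oxy gives an at least 2.0-fold lower number from compound 1 to compound 3 (0.31 log units; beyond the scatter), the first readable effect at this oxygen. The free hydroxy on the saturated carbon is therefore not required for a measurable value, and the ester is tolerated on this core. From the compounds shown here alone, the true size of the step remains unknown because compound 1 carries a limit of the assay and not a number: the limit of > 100000 nM in this assay, at which 1 of the 3 values shown sits.

Going by these compounds, it remains open whether an acetyl group, a benzoyl group or a simple methyl ether on this oxygen would shift the value further, and so whether the change depends on the carbonyl or on the sec-butyl chain. On these data alone, the effect of the same ester on the core of compound 2 also remains open.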